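The source may report more compounds than this note shows. Statements on the series, on what has been measured and on what is new or still open speak of the compounds shown alone.

Measured compounds in a functional assay on HT-29 cells (Homo sapiens) for antiproliferative activity, read by sulforhodamine B assay, with a stated time of 48 h; on this read-out higher numbers stand for weaker inhibition and lower numbers for stronger inhibition:

Compound 1 `COc1ccccc1OS(=O)(=O)c1ccc(N2CCN(C)C2=O)cc1` gives 26000 nM.
Compound 2 `Cc1ccc(OS(=O)(=O)c2ccc(N3CCN(C)C3=O)cc2)cc1` gives only a limit of the assay, > 100000 nM.
Compound 3 `COc1ccc(OS(=O)(=O)c2ccc(N3CCN(C)C3=O)cc2)cc1` gives only a limit of the assay, > 100000 nM.

Compound 2 is one of the two compounds that sit at the limit (the limit of > 100000 nM in this assay, at which 2 of the 3 values shown sit), so all that is known of it is that its inhibition is weaker than compound 1. The measured steps all change the aryl group on the oxygen: an at least 3.8-fold higher number from compound 1 to compound 2 (0.58 log units; beyond the scatter), an at least 3.8-fold higher number from compound 1 to compound 3 (0.58 log units; beyond the scatter), and a step that the two limits leave unreadable from compound 2 to compound 3.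

Compound 4 `CCCN1CCN(c2ccc(S(=O)(=O)Oc3ccc(C)cc3)cc2)C1=O` differs from compound 2 at the other end of the shared core: ethyl in place of hydrogen on a saturated chain carbon bound to an amide-type nitrogen in a ring. Going by the values given here, none of the measured steps touches this part of the molecule, so none of them bears on the step from compound 2 to compound 4, and there is no measured guide to its size or direction. Starting from a compound that already sits at the limit, compound 4 is expected to stay near that limit, with a step of a number no higher from compound 2 to compound 4 (the limit leaves the size open), meaning none beyond the scatter. In this assay compound 4 is therefore estimated at 100000 nM, within a range from 30000 nM to 300000 nM, with a good chance that only a limit is reported.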

Compound 4, half-maximal inhibitory concentration: 25000 nM
The estimate for compound 4 lay 4.0-fold (0.60 log units) above the measured number; the measured number lies below the stated range.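

In this assay, every earlier readable step changed the aryl group on the oxygen, and those steps gave no information about the other end of the shared core. This result shows that the other end also affects the read-out: replacing methyl with propyl on the amide-type nitrogen in the ring gives an at least 4.0-fold lower number from compound 2 to compound 4 (0.60 log units; beyond the scatter), and compound 4 has a measured number rather than a limit. The full size of this step cannot be read because compound 2 has only a limit and no exact value: the limit of > 100000 nM in this assay, at which 2 of the 4 values shown sit.

It remains open how the read-out follows the chain on this nitrogen, as the compounds shown carry only methyl and propyl there, and an ethyl or butyl chain, a longer chain, or a chain ending in an amine or a carboxylic acid could give a different result. From the compounds shown here alone, it is also open whether propyl would lower the number in the same way with 2-methoxyphenyl or 4-methoxyphenyl on the oxygen, as it appears here only with 4-methylphenyl.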